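Swapping the Dichlorobenzyl Group in a Sulfonamide Series

The source may hold more compounds than are shown below. What is called first, only, known or untested is meant among the compounds shown, and "the series" means these compounds.

Three compounds have been measured in a functional assay on HT-29 cells (Homo sapiens) for inhibition, read by MTT assay, with a stated time of 72 h; a lower number here means a stronger inhibitor of growth, a higher number a weaker inhibitor of growth:

Compound 1 `O=S(=O)(NCCCNCc1ccc(Cl)c(Cl)c1)c1cc(C(F)(F)F)cc(C(F)(F)F)c1` gives 4700 nM.
Compound 2 `O=S(=O)(NCCCNCc1ccc(Cl)c(C(F)(F)F)c1)c1cc(C(F)(F)F)cc(C(F)(F)F)c1` gives 11000 nM.
Compound 3 `O=S(=O)(NCCCNCc1ccccc1)c1cc(C(F)(F)F)cc(C(F)(F)F)c1` gives 15000 nM.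

Compound 1 stands at the lowest number of the three, which means it is the strongest growth inhibitor measured so far. Its nearest neighbour is compound 2, reached by a step of a 2.3-fold higher number from compound 1 to compound 2 (0.37 log units; beyond the scatter). The furthest is compound 3, reached by a 3.2-fold higher number from compound 1 to compound 3 (0.50 log units; beyond the scatter).

The next compound, compound 4 `COc1cccc(CNCCCNS(=O)(=O)c2cc(C(F)(F)F)cc(C(F)(F)F)c2)c1`, differs from compound 1 in one place:
3-methoxyphenyl in place of 3,4-dichlorophenyl on a saturated chain carbon bound to an amine nitrogen

Going by the values given here, two measured steps bear on this change. The step to compound 3 strips away both chlorines of the benzyl group and raises the number by a modest amount; the step to compound 2 exchanges one chloro and also raises it modestly. Compound 4 likewise loses both chlorines and gains a single methoxy group, so a modest rise beyond the scatter is expected, that is, weaker growth inhibition. The estimate for compound 4 is 12000 nM, with a range from 5000 nM to 30000 nM, corresponding to an expected step of a 2.6-fold higher number from compound 1 to compound 4 (0.41 log units; beyond the scatter).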

Compound 4, concentration for 50% growth inhibition: 10000 nM
Compound 4: the middle estimate sits 1.2-fold (0.08 log units) above what was measured, and the stated range covers the measured number.
By their numbers in this assay, from the lowest: compound 1; then compounds 4, 2 and 3 (each within the scatter of the next).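

In this assay, a single 3-methoxy group does not match the pair of chlorines: replacing 3,4-dichlorophenyl gives a 2.1-fold higher number from compound 1 to compound 4 (0.33 log units; beyond the scatter) and leaves compound 1 as the strongest growth inhibitor of the four. Adding methoxy to the bare phenyl ring gives a 1.5-fold lower number from compound 3 to compound 4 (0.18 log units; within the scatter) and the exchange for 4-chloro-3-(trifluoromethyl)phenyl gives a 1.1-fold lower number from compound 2 to compound 4 (0.04 log units; within the scatter) so compounds 2, 3 and 4 cannot be told apart, however different their rings look. No measurement at hand explains why only the 3,4-dichlorophenyl group stands apart.

Still open, from the compounds shown here alone, is whether one chlorine alone would keep the lead of compound 1, or whether a ring bearing a nitrile or a carboxylic acid would read differently. A longer chain in the core, or an amide in place of the amine, is also an open question.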